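The source may hold more compounds than are shown below. What is called first, only, known or untested is meant among the compounds shown, and "the series" means these compounds.

Two compounds of the series have been run in a functional assay on the whole organism (strain Zucker) for inhibition, with Rattus norvegicus as the target, with a stated time of 4 h, at a dose of 10 mg/kg by the oral route; on this read-out lower numbers stand for less inhibition and higher numbers for more inhibition at the one dose given (going by the name of the read-out). Compound 1 `CCCCCc1ccc(C2CC(C(=O)NN3CCOCC3)=NN2c2ccc(Cl)cc2Cl)cc1` gives 13.1% in this assay. Compound 2 `COc1ccc(C2CC(C(=O)NN3CCOCC3)=NN2c2ccc(Cl)cc2Cl)cc1` gives 9.4% in this assay; numerically this is the smaller of the two numbers on record, but the gap to compound 1 lies within the scatter, so the two cannot be told apart. Among the compounds with values here, the single step measured so far, a number 3.7 percentage points lower from compound 1 to compound 2 (within the scatter), swaps the substituent on the aryl that sits on the saturated ring carbon of the shared core.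

Compound 3 `O=C(NN1CCOCC1)C1=NN(c2ccc(Cl)cc2Cl)C(c2cccnc2)C1` is not yet measured. It differs from compound 2 by pyridin-3-yl in place of 4-methoxyphenyl on a saturated ring carbon. Within the data shown here, the one measured step touches this same aryl, and it stayed within the scatter; on that basis no step beyond the scatter is expected from this exchange either, a number 0.6 percentage points higher from compound 2 to compound 3 (within the scatter). Compound 3 is therefore estimated at 10% in this assay, with a range from 0% to 24%.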

Compound 3, a percentage reported as inhibition, in the whole organism at one dose (the size of the read-out at that dose, not a potency): 4%
Beside the measured number, compound 3's estimate is 6 percentage points above it, and the stated range covers the measured number.
By their numbers in this assay, from the lowest: compounds 3, 2 and 1 (each within the scatter of the next).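

Within this assay, this position now also takes an aryl with a ring hetero atom, and the reading does not leave the scatter: pyridin-3-yl in place of 4-methoxyphenyl gives (a number 5.4 percentage points lower from compound 2 to compound 3 (within the scatter)) and pyridin-3-yl in place of 4-pentylphenyl gives (a number 9.1 percentage points lower from compound 1 to compound 3 (within the scatter)). On the saturated ring carbon, 4-pentylphenyl, 4-methoxyphenyl and pyridin-3-yl therefore cannot be told apart at the one dose given, whether the exchange removes the pentyl chain or puts a ring nitrogen into the aryl. No measurement at hand accounts for this reading.

Still open, on these data alone, is whether a carboxylic acid or an amine on this aryl would give a step beyond the scatter. Also open, as far as these compounds go, is what replacing the 2,4-dichlorophenyl group or the (morpholin-4-yl)carbamoyl group would do to the number.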